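The source may report more compounds than this note shows. Statements on the series, on what has been measured and on what is new or still open speak of the compounds shown alone.

Compound 1, with the structure `O=C(Nc1ccccc1O)c1cccc(N2C(=O)c3ccccc3C2=O)c1`, is the reference point of this small set. In an in vitro functional assay on HEK293-A cells for antagonist activity at metabotropic glutamate receptor 5 (Rattus norvegicus), read by calcium flux (on this read-out higher numbers stand for weaker inhibition and lower numbers for stronger inhibition), compound 1 gives 77 nM. Compound 2 has the structure `O=C(Nc1cccnc1)c1cccc(N2C(=O)c3ccccc3C2=O)c1` and differs from compound 1 only in carrying a pyridin-3-yl group in place of the 2-hydroxyphenyl group on the amide-type nitrogen. In this assay compound 2 reaches only a limit, > 30000 nM, and no exact number is known for it. The step of an at least 380-fold higher number from compound 1 to compound 2 (2.59 log units; beyond the scatter) therefore shows a loss of inhibition that is at least this large, the value of compound 2 sitting at the limit of > 30000 nM in this assay, at which 1 of the 2 values shown sits. Compound 3 has the structure `O=C(Nc1ccccn1)c1cccc(N2C(=O)c3ccccc3C2=O)c1`. It differs from compound 2 in one place: pyridin-2-yl in place of pyridin-3-yl on an amide-type nitrogen. Within the data shown here, the only measured step touching this position is the one from compound 1 to compound 2, and it was large; no measured step swaps one pyridyl isomer for another, so the direction of the present change rests on a single data point at a limit. The expected step is an at least 3.7-fold lower number from compound 2 to compound 3 (0.57 log units; beyond the scatter), towards stronger inhibition but with wide uncertainty. For compound 3 the expected value in this assay is 8000 nM, within a range from 1000 nM to 30000 nM.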

Compound 3, half-maximal inhibitory concentration: 1260 nM
Estimate against measurement, compound 3: 6.3-fold (0.80 log units) above, and the stated range covers the measured number.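

Exchanging pyridin-3-yl for pyridin-2-yl on the amide-type nitrogen keeps the same atoms but joins them differently, and in this assay this change gives an at least 23-fold lower number from compound 2 to compound 3 (1.37 log units; beyond the scatter), so this position distinguishes between two pyridyl isomers and does not respond merely to the presence of a pyridine ring. On these data alone, the true size of that step remains unknown because compound 2 has only a limit and no exact value: the limit of > 30000 nM in this assay, at which 1 of the 3 values shown sits. Pyridin-2-yl recovers only part of the earlier loss, since the comparison with the 2-hydroxyphenyl group still shows a 16-fold higher number from compound 1 to compound 3 (1.21 log units; beyond the scatter), which means that neither pyridyl group shown matches the 2-hydroxyphenyl group at this position.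

The compounds shown leave open how pyridin-4-yl, plain phenyl or 2-methoxyphenyl would behave on the same nitrogen, and these groups could help show whether the hydroxyl group of compound 1 matters on its own. They also leave open why the two pyridyl isomers differ, and whether the same order would hold if the rest of the shared core were changed.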